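A boron-bearing group replaces a bromine-bearing one

A few compounds are considered here, and "the series" means these few. Any claim that something is new, unique, unknown or untested is made for them only; others in the source may bear on it.

Compound 1 `CC(C)CN(NC(=O)OCc1ccccc1)C(=O)CN(Cc1ccccc1)NC(=O)Cc1cccc(Br)c1` offers no exact potency to start from. In a functional assay on B16 cells (Mus musculus) for inhibition (a lower number here means a stronger inhibitor, a higher number a weaker inhibitor), compound 1 gives > 80000 nM, which is a limit of the assay and not a number. For the measured compounds named here, compound 2 `CC(C)CN(CC(=O)NN(Cc1ccccc1)c1cnccn1)NC(=O)Cc1cccc(Br)c1`, the only other measured compound, gives a number in this assay, at 23400 nM. Going by the values given here, no measured pair differs in one place only, so there is no direct precedent for the size of a step.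

Compound 3 `CC(C)CN(NC(=O)OCc1ccccc1)C(=O)CN(Cc1ccccc1)/N=C/c1ccccc1B(O)O` retains the core of compound 1 and changes at a single place, on an amine nitrogen: a group of 11 heavy atoms (7 carbon, 1 boron, 1 nitrogen, 2 oxygen; one six-membered aromatic ring of carbon only) in place of a group of 11 heavy atoms (8 carbon, 1 nitrogen, 1 oxygen, 1 bromine; one six-membered aromatic ring of carbon only), on an amine nitrogen. A moderate step towards stronger inhibition is expected, though compound 3 could also remain at the limit of this assay. Among the compounds with values here, compound 2, at 23400 nM, gives the only numerical guide to where a measurable result might fall. The estimated step is an at least 3.2-fold lower number from compound 1 to compound 3 (0.50 log units; beyond the scatter), and its size is uncertain. For compound 3 the estimated value is 25000 nM, with an expected range of 6000 nM to 80000 nM.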

Compound 3, half-maximal inhibitory concentration: 65500 nM
Estimate against measurement, compound 3: 2.6-fold (0.42 log units) below; measured number inside the range.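

In this assay compound 3 gives a number where compound 1 gives only a limit of the assay, so this place on the amine nitrogen now has its first exact reading on the core of compound 1. The exchange of the bromine-bearing group for the boron-bearing group amounts to an at least 1.2-fold lower number from compound 1 to compound 3 (0.08 log units; that floor lies within the scatter), which shows that a measurable result is possible at this place but does not establish a real gain in strength. The step has a floor and no upper bound, and the limit held by compound 1 sets how far it can be read: the limit of > 80000 nM in this assay, at which 1 of the 3 values shown sits.

The compounds shown leave open which part of the entering group matters, since the boron-bearing group and the bromine-bearing group differ in more than one feature, and whether a carboxylic acid or an amine carried on the same aromatic ring would read any differently. They also leave open whether the same exchange would move compound 2, which gives 23400 nM, in the same direction on its own core.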